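Bromine Added to a Shared Core: Expecting Compound 4

A few compounds are considered here, and "the series" means these few. Any claim that something is new, unique, unknown or untested is made for them only; others in the source may bear on it.

In a functional assay on A549 cells (Homo sapiens) for cytotoxicity, read by MTT assay, with a stated time of 4 days (a lower number here means a stronger inhibitor, a higher number a weaker inhibitor), compound 1 `C=C1C[C@]23C[C@@]1(O)CC[C@@H]2c1cccc(C)c1[C@@H]3Cn1cc(-c2ccc(Br)cc2)nn1` gives > 20000 nM, which is a limit of the assay and not a number.
In this assay compound 2 `C=C1C[C@]23C[C@@]1(O)CC[C@@H]2c1cccc(C)c1[C@@H]3Cn1cc(-c2ccccc2)nn1` gives > 20000 nM, again a limit of the assay.
In this assay compound 3 `C=C1C[C@]23C[C@@]1(O)CC[C@H]2c1ccc(O)c(C)c1[C@@H]3Cn1cc(-c2ccc(C)cc2)nn1` gives > 20000 nM, likewise a limit of the assay.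

All three measured compounds sit at the same ceiling, so no order among them can be read. The change from compound 2 to compound 1, (bromo in place of hydrogen on an aromatic carbon), gives a step that the two limits leave unreadable from compound 2 to compound 1; the reason it cannot be sized is the limit of > 20000 nM in this assay, at which 3 of the 3 values shown sit, the limit shared by every value shown. How the core of compound 3 differs from that of compound 2 is not broken down here.

Compound 4 `C=C1C[C@]23C[C@@]1(O)CC[C@H]2c1cc(Br)c(O)c(C)c1[C@@H]3Cn1cc(-c2ccc(C)cc2)nn1` is not yet measured. It differs from compound 3 by bromo in place of hydrogen on an aromatic carbon. This is the same kind of change as that from compound 2 to compound 1, but not the same: there the bromo entered para to a large group, whereas in compound 4 it enters ortho to a hydroxy group, meta to a fused ring, meta to a methyl group and para to a fused ring, within the fused or bridged system of four rings.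

Among the measured compounds shown here, since compound 3 shows only > 20000 nM and the one comparable step is unreadable, compound 4 is expected to show a step that the limit leaves unreadable from compound 3 to compound 4, that is, no step that can be distinguished. Compound 4 is therefore estimated at 30000 nM, most likely reported again as a limit, with a range of 8000 nM to 100000 nM.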

Compound 4, half-maximal inhibitory concentration: > 20000 nM
Compound 4: no number, only a limit (the forecaster's own chance of this, stated with the estimate: 80%); the middle value lies beyond the limit too.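

Compound 4, like compound 3, gives only a limit of the assay in this assay and not a number, so no step can be read between the two: the limit of > 20000 nM in this assay, at which 4 of the 4 values shown sit.

The compounds shown leave open whether bromo in place of hydrogen on an aromatic carbon changes the read-out in this assay at all, and how any of these compounds would rank against another.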